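This account rests on a few compounds, and the source may have more. Where it says the series, first, only, none or still open, it means among the compounds named here.

Compound 1 `Cc1cc(Nc2cc(-c3ccccc3)[nH]n2)n2nc(SCc3ccc(Br)cc3)nc2n1` gives 39300 nM in an ADME assay on GES1 cells (Homo sapiens) for inhibition, read by MTT assay, with a stated time of 72 h; a higher number here means a weaker inhibitor, a lower number a stronger inhibitor. Compound 3 `C#CCSc1nc2nc(C)cc(Nc3cc(-c4ccccc4)[nH]n3)n2n1` gives 45700 nM in this assay, and the step of a 1.2-fold higher number from compound 1 to compound 3 (0.07 log units; within the scatter) leaves the two numbers within the scatter of each other. Compound 2 `Cc1cc(Nc2cc(C(C)(C)C)[nH]n2)n2nc(SCc3ccc(Br)cc3)nc2n1` reaches only a limit of the assay, > 50000 nM, the one limit among the three values (the limit of > 50000 nM in this assay, at which 1 of the 3 values shown sits); the step of an at least 1.2-fold higher number from compound 1 to compound 2 (0.10 log units; that floor lies within the scatter) can thus be sized only to its floor. Compound 4 `Cc1cc(Nc2cc(-c3ccccc3)[nH]n2)n2nc(SCC3CC3)nc2n1` differs from compound 3 by cyclopropyl in place of ethynyl on a saturated chain carbon bound to a sulfur. The step at the same place, a 1.2-fold higher number from compound 1 to compound 3 (0.07 log units; within the scatter), stayed within the scatter, so no movement beyond the scatter is expected in this assay. Compound 4 is therefore estimated at 44000 nM, between 24000 nM and 80000 nM. The estimated step is a 1.0-fold lower number from compound 3 to compound 4 (0.02 log units; within the scatter).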

Compound 4, half-maximal inhibitory concentration: > 50000 nM
Compound 4 gave a limit, no number (the forecaster's own chance of this, stated with the estimate: 35%); at least 1.1-fold (0.05 log units) between middle value and limit.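

After 4-bromophenyl and ethynyl, cyclopropyl is a third group on the saturated chain carbon bound to a sulfur, and with it compound 4 gives only a limit in this assay, not a number. The steps of an at least 1.0-fold higher number from compound 3 to compound 4 (0.03 log units; that floor lies within the scatter) and an at least 1.2-fold higher number from compound 1 to compound 4 (0.10 log units; that floor lies within the scatter) can be sized only to their floors, so neither shows a movement beyond the scatter. Compound 4 now stands at the same limit as compound 2: the limit of > 50000 nM in this assay, at which 2 of the 4 values shown sit.

Going by these compounds, whether an amine or a carboxylic acid at this place would give a much lower number remains open.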